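This account rests on a few compounds, and the source may have more. Where it says the series, first, only, none or still open, it means among the compounds named here.

Measured so far in an ADME assay on HEK-293T cells (Homo sapiens) for cytotoxicity, read by MTT assay, with a stated time of 48 h; a higher number here means that more compound is tolerated, a lower number that less compound is tolerated:
compound 1, `CC1(C)[C@H]2CC[C@]1(C)[C@H](OC(=O)CN1CCCCC1)C2`: 141000 nM
compound 2, `CC1CCN(CC(=O)O[C@@H]2C[C@@H]3CC[C@@]2(C)C3(C)C)CC1`: 71600 nM
compound 3, `CN1CCN(CC(=O)O[C@@H]2C[C@@H]3CC[C@@]2(C)C3(C)C)CC1`: 313000 nM

Compound 3 stands highest of the three in this assay: there is a 2.2-fold higher number from compound 1 to compound 3 (0.35 log units; beyond the scatter), and there is a 4.4-fold higher number from compound 2 to compound 3 (0.64 log units; beyond the scatter), both beyond the scatter. Compound 4, `CCN1CCN(CC(=O)O[C@@H]2C[C@@H]3CC[C@@]2(C)C3(C)C)CC1`, is the next step from compound 3. The change is methyl in place of hydrogen on a saturated chain carbon bound to an amine nitrogen in a ring.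

Among the measured compounds shown here, only one measured step resembles this: the step of a 2.0-fold lower number from compound 1 to compound 2 (0.29 log units; within the scatter), which also adds a methyl in place of hydrogen, though on a saturated ring carbon rather than on a saturated chain carbon bound to an amine nitrogen in a ring, and it stayed within the scatter. For the measured compounds named here, no measured pair adds a carbon on the amine nitrogen side of the ring. On that basis compound 4 is expected to sit close to compound 3, with at most a small move and none that clearly exceeds the scatter; the expected step is a 1.3-fold lower number from compound 3 to compound 4 (0.10 log units; within the scatter). Compound 4 is therefore estimated at 250000 nM, within a range from 120000 nM to 500000 nM.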

Compound 4, half-maximal cytotoxic concentration: 130000 nM
The estimate for compound 4 lay 1.9-fold (0.28 log units) above the measured number; the range from low to high includes it.
By their numbers in this assay, from the lowest: compounds 2, 4 and 1 (each within the scatter of the next); then compound 3.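

In this assay, lengthening methyl to ethyl on the saturated chain carbon bound to an amine nitrogen in a ring gives a 2.4-fold lower number from compound 3 to compound 4 (0.38 log units; beyond the scatter) and so moves the number beyond the scatter. Among the compounds shown here, the only earlier methyl-for-hydrogen step, on a saturated ring carbon, was a 2.0-fold lower number from compound 1 to compound 2 (0.29 log units; within the scatter) and stayed within the scatter, so this is the first sign that a single added carbon at this place on the ring nitrogen can lower the tolerated concentration measurably. Nothing available accounts for this shift.

The compounds shown leave open whether a longer chain such as propyl, or a ring such as cyclopropyl, would carry the fall further at this place or leave the number unchanged. They also do not tell whether a hydroxyethyl group would behave like ethyl here.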